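A group swap at the edge of measurement

The compounds below may be only part of what the source reports. "The series", "measured", "known", "first", "only" and "open" are said of these compounds alone.

Compound 1 `CC(C)N(Cc1cccc(OCCCCCC(=O)O)c1)C(=O)c1ccccc1` gives > 26000 nM in an ADME assay on BJ cells (Homo sapiens) for cytotoxicity, read by CellTiter-Glo and resazurin assay, with a stated time of 72 h (on this read-out lower numbers stand for an effect already at smaller amounts and higher numbers for an effect only at larger amounts of compound), and that reading is a limit, not a number. Compound 2 `CC(C)N(Cc1cccc(OCCCCCC(=O)O)c1)C(=O)c1ccc(-c2ccc3cc[nH]c3c2)cc1` gives > 26000 nM as a reading that is again only a limit. Compound 3 `CC(C)N(Cc1cccc(OCCCCCC(=O)O)c1)C(=O)c1ccc(-c2c[nH]c3ccccc23)cc1` gives > 26000 nM as its reading and this too is only a limit. Compound 3 therefore shares its place with compound 1 and compound 2, and no ranking among them is possible.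

The change to compound 4 `CC(C)N(Cc1cccc(OCCCCCC(=O)O)c1)C(=O)c1ccc(-c2cccc(C(F)(F)F)c2)cc1` is 3-(trifluoromethyl)phenyl in place of 1H-indol-3-yl on an aromatic carbon and it falls on an aromatic carbon of the shared core.

For the measured compounds named here, three measured steps bear on this change. Adding 1H-indol-6-yl gave a step that the two limits leave unreadable from compound 1 to compound 2 and adding 1H-indol-3-yl gave a step that the two limits leave unreadable from compound 1 to compound 3 while exchanging those two groups gave a step that the two limits leave unreadable from compound 2 to compound 3 as the third case. None of these steps has a readable size or direction. Going by the values given here, compound 3 shares the limit of > 26000 nM in this assay, at which 3 of the 3 values shown sit, and that is the only guide, so no step beyond the scatter is expected in this assay and another limit is the likeliest reading.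

The expected step is a step that the limit leaves unreadable from compound 3 to compound 4 on this estimate. For compound 4 the estimated value is 30000 nM with an expected range from 12000 nM to 60000 nM in this assay.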

Compound 4, half-maximal effective concentration: > 26000 nM
Compound 4 was reported as a limit (the forecaster's own chance of this, stated with the estimate: 75%); the middle value lies beyond the limit too.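

In this assay compound 4 gives > 26000 nM as a limit, not a number. Its steps from compound 1, compound 2 and compound 3 therefore cannot be read in size or direction: the limit of > 26000 nM in this assay, at which 4 of the 4 values shown sit. The compounds shown leave open how far apart these four compounds truly lie in this assay and whether any of the added groups makes a difference at all.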